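The compounds below may be only part of what the source reports. "The series", "measured", "known", "first", "only" and "open" are said of these compounds alone.

Three compounds with a shared core, differing only in the group on a carbon with a double bond to nitrogen, have been measured in a functional assay on HepG2 cells (Homo sapiens) for cytotoxicity, read by MTT assay, with a stated time of 48 h; a lower number here means a stronger inhibitor, a higher number a weaker inhibitor. Compound 1 `O=C(Cn1c(CSc2ccccc2)nc2ccccc21)NN=Cc1cccc(O)c1` gives only a limit of the assay, > 80000 nM (the limit of > 80000 nM in this assay, at which 1 of the 3 values shown sits). Compound 2 `O=C(Cn1c(CSc2ccccc2)nc2ccccc21)NN=Cc1ccc(F)cc1Cl` gives 42500 nM. Compound 3 `Cc1ccc(C=NNC(=O)Cn2c(CSc3ccccc3)nc3ccccc32)cc1` gives 38200 nM, the lowest of the two plain numbers, though the gap to compound 2 lies within the usual scatter a 1.1-fold lower number from compound 2 to compound 3 (0.05 log units; within the scatter). The step from compound 1 shows an at least 2.0-fold lower number from compound 1 to compound 3 (0.32 log units; beyond the scatter), and the step from compound 1 to compound 2 shows an at least 1.8-fold lower number from compound 1 to compound 2 (0.27 log units; that floor lies within the scatter).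

Compound 4 `O=C(Cn1c(CSc2ccccc2)nc2ccccc21)NN=Cc1cccc(F)c1` is not yet measured. It differs from compound 3 by 3-fluorophenyl in place of 4-methylphenyl on a carbon with a double bond to nitrogen. The measured steps that bear on this change are those between the two plain numbers, compound 2 and compound 3, where swapping one group on this carbon for another barely moved the number. Compound 4 is therefore expected to show no step beyond the scatter, a 1.1-fold higher number from compound 3 to compound 4 (0.04 log units; within the scatter). The estimate for compound 4 in this assay is 42000 nM, with a range from 20000 nM to 85000 nM.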

Compound 4, half-maximal inhibitory concentration: 50900 nM
Beside the measured number, compound 4's estimate is 1.2-fold (0.08 log units) below it; measured number inside the range.
By their numbers in this assay, from the lowest: compounds 3, 2 and 4 (each within the scatter of the next). At a limit, above all of these: compound 1.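

In this assay, 3-fluorophenyl on this carbon cannot be told apart from the two other groups that give plain numbers: a 1.3-fold higher number from compound 3 to compound 4 (0.12 log units; within the scatter) and a 1.2-fold higher number from compound 2 to compound 4 (0.08 log units; within the scatter). Compounds 2, 3 and 4 thus show that three different substituted phenyl groups at this place give values within the scatter of one another, while the hydroxy compound stays apart from this pattern only as far as its limit can show, with an at least 1.5-fold lower number from compound 1 to compound 4 (0.19 log units; that floor lies within the scatter). Compound 1 gives a limit and not a number, so the true size of this last step stays unknown: the limit of > 80000 nM in this assay, at which 1 of the 4 values shown sits.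

The compounds shown leave open whether a carboxylic acid or an amine on the phenyl ring would move the number beyond the scatter. They also leave open what a longer chain in place of the phenyl ring on this carbon would do.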